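The source may report more compounds than this note shows. Statements on the series, on what has been measured and on what is new or still open speak of the compounds shown alone.

Measured so far:
- compound 1 `CN(C)c1ccc(N2C(=O)NC3(CSC4=C3C(=O)c3ncccc3C4=O)C2=O)cc1`: 800 nM
- compound 2 `O=C1NN(c2ccccc2)C(=O)C2(CSC3=C2C(=O)c2ncccc2C3=O)N1`: 4550 nM

In a functional assay on XF498 cells (Homo sapiens) for antiproliferative activity, read by MTT assay, with a stated time of 96 h (a higher number here means a weaker inhibitor, a lower number a stronger inhibitor), compound 1 gives 800 nM, the lower of the two numbers recorded. Compound 2 gives 4550 nM, and the gap between the two lies beyond the usual scatter. Going by the values given here, compound 2 differs from compound 1 in more than one place, so no single-point step between measured compounds is available and the effect of any one change remains unknown.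

Compound 3 `O=C1C2=C(C(=O)c3ncccc31)C1(CS2)NC(=O)N(c2ccncc2)C1=O` is the next candidate; its change from compound 1 is pyridin-4-yl in place of 4-(dimethylamino)phenyl on an amide-type nitrogen in a ring. Among the compounds with values here, no measured pair reports this exchange. The expectation is a small weakening, a 1.9-fold higher number from compound 1 to compound 3 (0.27 log units; within the scatter), at the edge of the scatter rather than clearly beyond it, with the value of compound 2 as a loose ceiling. Compound 3 is therefore estimated at 1500 nM, with a range from 500 nM to 5000 nM.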

Compound 3, half-maximal inhibitory concentration: 1120 nM
Compound 3: middle estimate off by 1.3-fold (0.13 log units), on the high side; the measured number falls inside the stated range.
By their numbers in this assay, from the lowest: compounds 1 and 3 (each within the scatter of the next); then compound 2.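

In this assay, going by these compounds alone, pyridin-4-yl in place of 4-(dimethylamino)phenyl on the amide-type nitrogen gives the only single-place step so far (a 1.4-fold higher number from compound 1 to compound 3 (0.15 log units; within the scatter)). At this position, an aromatic ring with a ring nitrogen and 6 heavy atoms reads within the scatter of a carbon-only aromatic ring carrying a dimethylamino group, with 9 heavy atoms in all, so the dimethylamino group is not needed for a value in this range. No measurement at hand accounts for the two groups reading alike.

Still open, from the compounds shown here alone, is how a plain phenyl group or a 4-aminophenyl group on the same nitrogen would read, which would separate the contribution of the dimethylamino group from that of the ring. Going by these compounds, the effect of changes elsewhere on the shared core also remains unknown.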